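Phenyl in place of benzyl on a shared core

The compounds below may be only part of what the source reports. "The series", "measured", "known", "first", "only" and "open" are said of these compounds alone.

Compound 1 `COc1cc2nccc(Oc3ccc4c(NCc5ccccc5)nn(C)c4c3)c2cc1OC`: > 1000 nM
Compound 2 `COc1cc2nccc(Oc3ccc4c(NC(=O)c5cc(Cl)ccn5)nn(C)c4c3)c2cc1OC`: > 1000 nM
Compound 3 `COc1cc2nccc(Oc3ccc4c(NC(=O)Nc5ccc(C)cc5)nn(C)c4c3)c2cc1OC`: > 1000 nM

In a functional assay on HUVEC cells (Homo sapiens) for inhibition, with stated times of 2 h and 72 h (a higher number here means a weaker inhibitor, a lower number a stronger inhibitor), compound 1 gives only a limit, > 1000 nM, not a number. Compound 2 likewise sits at a limit, > 1000 nM. Compound 3 also sits at a limit, > 1000 nM. For the measured compounds named here, because of the limit of > 1000 nM in this assay, at which 3 of the 3 values shown sit, the measured steps a step that the two limits leave unreadable from compound 1 to compound 2, a step that the two limits leave unreadable from compound 1 to compound 3 and a step that the two limits leave unreadable from compound 2 to compound 3 cannot be read in size or direction: the three values give no ordering among the compounds.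

Compound 4 `COc1cc2nccc(Oc3ccc4c(Nc5ccccc5)nn(C)c4c3)c2cc1OC` differs from compound 1 by phenyl in place of benzyl on a nitrogen on an aromatic ring. Going by the values given here, none of the measured steps makes this same change, so no step bears on it directly; what the three compounds show is only that every value so far is a limit. The step that the limit leaves unreadable from compound 1 to compound 4 is therefore expected to be none that can be read beyond the scatter, with compound 4 most likely reported as a limit too. Compound 4 is estimated at 2000 nM, within a range from 600 nM to 10000 nM.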

Compound 4, half-maximal inhibitory concentration: > 1000 nM
Compound 4 ended at the assay's limit; the forecaster's own chance of this, stated with the estimate: 75%; the middle value does not contradict the limit.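

The steps to compound 4 from compound 1, compound 2 and compound 3 cannot be read in size or direction in this assay, because all four compounds sit at one limit: the limit of > 1000 nM in this assay, at which 4 of the 4 values shown sit.

As far as these compounds go, whether compound 1, compound 2, compound 3 and compound 4 differ at all as inhibitors stays open.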